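Halogen swap on the amide aryl ring of compound 3

The compounds below may be only part of what the source reports. "The series", "measured", "known", "first", "only" and "open" are said of these compounds alone.

Measured so far in an assay on isolated protein (Mus musculus) for inhibition of IL15-IL15 receptor (Homo sapiens), read by resazurin assay, with stated times of 30 min and 2.5 days; on this read-out higher numbers stand for weaker inhibition and lower numbers for stronger inhibition:
compound 1 `Cn1c(Cc2nn(C)c(=O)c3ccccc23)nnc1SCC(=O)Nc1ccc(O)cc1` — "not active" (no number reported)
compound 2 `CN(C(=O)CCCCCCCSc1nnc(Cc2nn(C)c(=O)c3ccccc23)n1C)c1ccc(Cl)cc1Cl` — 11900 nM
compound 3 `Cn1c(Cc2nn(C)c(=O)c3ccccc23)nnc1SCCCCCCCC(=O)Nc1ccc(Br)cc1Br` — 1500 nM

Compound 3 `Cn1c(Cc2nn(C)c(=O)c3ccccc23)nnc1SCCCCCCCC(=O)Nc1ccc(Br)cc1Br` holds the lowest of the two numbers reported; its nearest neighbour is compound 2, and the step of a 7.9-fold lower number from compound 2 to compound 3 (0.90 log units; beyond the scatter) lies beyond the scatter. Compound 1 gave no number in this assay and so cannot be placed against the other two.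

Compound 4 `Cn1c(Cc2nn(C)c(=O)c3ccccc23)nnc1SCCCCCCCC(=O)Nc1ccc(F)cc1F` differs from compound 3 in one place: 2,4-difluorophenyl in place of 2,4-dibromophenyl on an amide-type nitrogen. Among the compounds with values here, no measured pair isolates a halogen exchange on this ring. Within the data shown here, the only step that touches the aryl amide end, a 7.9-fold lower number from compound 2 to compound 3 (0.90 log units; beyond the scatter), changes both the halogens and the amide nitrogen substitution at once, so it does not separate the contribution of bromine from that of the methyl group. Compound 1 carries a different chain and a hydroxyphenyl group and gives no number, so it offers no guide either.

Among the measured compounds shown here, with no directly comparable step in hand, the expectation for compound 4 is a step of a 2.0-fold higher number from compound 3 to compound 4 (0.30 log units; within the scatter), which is held close to the scatter but with a wide range. Compound 4 is estimated at 3000 nM, between 800 nM and 12000 nM.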

Compound 4, half-maximal inhibitory concentration: 2300 nM
For compound 4 the middle estimate is 1.3-fold (0.12 log units) above the measured one; low and high end bracket the measured number.
By their numbers in this assay, from the lowest: compounds 3 and 4 (each within the scatter of the next); then compound 2.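

In this assay, within the data shown here, the exchange of 2,4-dibromophenyl for 2,4-difluorophenyl on the amide-type nitrogen gives a 1.5-fold higher number from compound 3 to compound 4 (0.19 log units; within the scatter), so for the first time a halogen change on this ring is seen alone, and within these two compounds the read-out does not tell bromine from fluorine. The second new step, a 5.2-fold lower number from compound 2 to compound 4 (0.71 log units; beyond the scatter), places compound 2 apart from compound 4 as well as from compound 3, which suggests that the choice of halogen alone does not account for the earlier gap, although chlorine and the methyl group on the amide nitrogen still change together in both steps. The data shown include no measurement that explains either step.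

The compounds shown leave open how much of the gap belongs to that methyl group and how much to chlorine, a question that a 2,4-dichlorophenyl ring on a nitrogen carrying the amide hydrogen would address. They also leave open whether any halogen is needed at all, as an unsubstituted phenyl ring or one bearing a methoxy group could show.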